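The source may hold more compounds than are shown below. What is called first, only, known or untested is meant among the compounds shown, and "the series" means these compounds.

In an ADME assay on S9 fraction from liver (Rattus norvegicus) for metabolic stability, read by LC-MS, using NADPH, with a stated time of 30 min (a higher number here means that more of the compound is left, a lower number that less of the compound is left), compound 1 (`CCCCCCCCc1ccc(OCC(=O)Cn2nnnc2SC)cc1`) gives 21%, compound 2 (`CCCCCCCCc1ccc(OCC(=O)Cn2nnnc2-c2cccc(S(=O)(=O)N(C)C)c2)cc1`) gives 24% and compound 3 (`CCCCCCCCc1ccc(OCC(=O)Cn2nnnc2-c2cccs2)cc1`) gives 27%, so compound 3 stands level with the other two once the usual scatter is allowed for. Compound 4 (`CCCCCCCCc1ccc(OCC(=O)Cn2nnnc2C(=O)OC)cc1`) carries methoxycarbonyl in place of thiophen-2-yl on an aromatic carbon. Three measured steps exchange the group at this same place: a number 3 percentage points higher from compound 1 to compound 2 (within the scatter), a number 6 percentage points higher from compound 1 to compound 3 (within the scatter) and a number 3 percentage points higher from compound 2 to compound 3 (within the scatter). Among the measured compounds shown here, all three stay within the scatter, so no step beyond it is expected here, although no measured compound carries methoxycarbonyl. The expected change is a number 5 percentage points lower from compound 3 to compound 4 (within the scatter). The estimated value for compound 4 is 22%, with an expected range of 8% to 36%.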

Compound 4, percent of the compound remaining: 38%
Compound 4: middle estimate off by 16 percentage points, on the low side, outside the stated range (above it).
By their numbers in this assay, from the lowest: compounds 1, 2 and 3 (each within the scatter of the next); then compound 4.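

In this assay the group on this aromatic carbon can matter after all: methoxycarbonyl gives a number 11 percentage points higher from compound 3 to compound 4 (beyond the scatter) and a number 14 percentage points higher from compound 2 to compound 4 (beyond the scatter) and also a number 17 percentage points higher from compound 1 to compound 4 (beyond the scatter) in the same direction. Methylsulfanyl, 3-(dimethylsulfamoyl)phenyl and thiophen-2-yl had all stayed within the scatter of one another, so compound 4 is the first here to stand apart from the rest. Nothing available explains this difference.
On these data alone, it remains open whether the effect belongs to methoxycarbonyl alone or extends to related groups. A carboxylic acid or a simple amide at this place could help settle that.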